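The source may report more compounds than this note shows. Statements on the series, on what has been measured and on what is new or still open speak of the compounds shown alone.

Working notes on the series

Four compounds share a common scaffold carrying methoxy-substituted aromatic rings; they differ only in the group attached to the core. Compound 1 `COc1ccc([C@@H]2c3c(OC)cc(OC)cc3/C(=C/c3ccccc3)[C@H]2c2cc(OC)cc(OC)c2)cc1` and compound 2 `COc1ccc([C@@H]2c3c(OC)cc(OC)cc3/C(=C/c3ccc(C)cc3)[C@H]2c2cc(OC)cc(OC)c2)cc1` have a benzylidene-type arm, while compound 3 `COc1ccc([C@@H]2c3c(OC)cc(OC)cc3C(SCc3ccccc3)[C@H]2c2cc(OC)cc(OC)c2)cc1` and compound 4 `COc1ccc([C@@H]2c3c(OC)cc(OC)cc3C(SCc3ccc(C)cc3)[C@H]2c2cc(OC)cc(OC)c2)cc1` have a benzylsulfanyl arm. How the two cores differ is not broken down here.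

In a functional assay on RAW264.7 cells (Mus musculus) for inhibition, with stated times of 2 h and 24 h (on this read-out lower numbers stand for stronger inhibition and higher numbers for weaker inhibition), compound 1 gives > 200000 nM, which is a limit of the assay and not a number. In this assay compound 2 gives > 200000 nM, again a limit. The change from compound 1 to compound 2 is methyl in place of hydrogen on an aromatic carbon, and a step that the two limits leave unreadable from compound 1 to compound 2. Of compound 3 this assay records > 200000 nM, also a limit. All three measured values therefore sit at the limit of > 200000 nM in this assay, at which 3 of the 3 values shown sit.

The change from compound 3 to compound 4 is methyl in place of hydrogen on an aromatic carbon; it is the same change as that from compound 1 to compound 2, made at the same kind of place, on a different core. For compound 4 in this assay the step that the limit leaves unreadable from compound 3 to compound 4 is expected to be unreadable in the same way, because compound 1 and compound 2 both sit at the limit of > 200000 nM in this assay, at which 3 of the 3 values shown sit, and compound 3 sits there too. Compound 4 is therefore estimated at 300000 nM, with the expected range running from 100000 nM to 1000000 nM, and most likely the assay will again report only a limit.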

Compound 4, half-maximal inhibitory concentration: > 200000 nM
Compound 4 was reported as a limit; the forecaster's own chance of this, stated with the estimate: 85%; the middle value lies beyond the limit too.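

Compound 3 and compound 4 both stand at a limit of this assay and not at a number, and no new step can be read between them. What the compounds shown leave open is how compound 1, compound 2, compound 3 and compound 4 rank against one another, and whether methyl in place of hydrogen changes anything on either core: the limit of > 200000 nM in this assay, at which 4 of the 4 values shown sit.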